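This account rests on a few compounds, and the source may have more. Where it says the series, first, only, none or still open, it means among the compounds named here.

Working notes on the series, all read in a functional assay on NCI-H1299 cells (Homo sapiens), read by flow cytometry; on this read-out higher numbers stand for an effect only at larger amounts of compound and lower numbers for an effect already at smaller amounts. Compound 1 `N#Cc1ncc2nc1OCC/C=C\COc1ccc(O)cc1NC(=O)N2`, carrying hydroxy on the aromatic carbon, gives > 10000 nM, which is a limit and not a number. Compound 2 `N#Cc1ncc2nc1OCC/C=C\COc1ccc(Br)cc1NC(=O)N2`, carrying bromo there, gives > 10000 nM, again a limit. Compound 3 `N#Cc1ncc2nc1OCC/C=C\COc1ccc(OCCOC3CCCCO3)cc1NC(=O)N2` gives > 10000 nM, also a limit. No number therefore places compound 3 within the series, and its standing is simply (the limit of > 10000 nM in this assay, at which 3 of the 3 values shown sit).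

The next change leads from compound 3 to compound 4 `N#Cc1ncc2nc1OCC/C=C\COc1ccc(CCCO)cc1NC(=O)N2`: 3-hydroxypropyl in place of 2-((oxan-2-yl)oxy)ethoxy on an aromatic carbon. In words, 3-hydroxypropyl stands in place of 2-((oxan-2-yl)oxy)ethoxy on an aromatic carbon. All three measured steps bear on this change, as each alters the same substituent: a step that the two limits leave unreadable from compound 1 to compound 2, a step that the two limits leave unreadable from compound 1 to compound 3 and a step that the two limits leave unreadable from compound 2 to compound 3. None of them has a readable size, so none supplies a size or direction to carry over to the new step. In this assay the expected outcome is a number no higher from compound 3 to compound 4 (the limit leaves the size open), with no direction expected from these data. The expectation rests on (the limit of > 10000 nM in this assay, at which 3 of the 3 values shown sit), so compound 4 is expected to lie close to that limit, and a reading at the limit is more likely than a number. For compound 4 the estimate is 10000 nM, with an expected range of 3000 nM to 30000 nM.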

Compound 4, half-maximal effective concentration: > 10000 nM
Compound 4: only a limit was reported; the forecaster's own chance of this, stated with the estimate: 70%; the middle value lies on the limit itself.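

In this assay compound 4 gives > 10000 nM, which is a limit and not a number. Its steps from compound 1, compound 2 and compound 3 therefore cannot be read. The compounds shown leave open how the substituent on this aromatic carbon affects the read-out, since none yields a number: the limit of > 10000 nM in this assay, at which 4 of the 4 values shown sit.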